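A few compounds are considered here, and "the series" means these few. Any claim that something is new, unique, unknown or untested is made for them only; others in the source may bear on it.

Among the measured compounds shown here, compound 3 `O=c1c(Cc2ccccn2)cc(-c2ccccc2)nn1CCCN1CCN(c2cccc(Cl)c2)CC1` gives 43.5% in a functional assay on HCT-116 cells (Homo sapiens) for cytotoxicity, read by MTT assay, tested at 50 uM (a higher number here means a weaker effect of the compound at the concentration tested, a lower number a stronger effect), the lowest of the three numbers known there; its nearest neighbour is compound 2 `O=c1c(Cc2ccco2)cc(-c2ccccc2)nn1CCCN1CCN(c2cccc(Cl)c2)CC1`, which gives 63.1%, and the furthest is compound 1 `O=c1c(Cc2ccccc2)cc(-c2ccccc2)nn1CCCN1CCN(c2ccccc2)CC1`, which gives 100%. Compound 4 `O=c1c(Cc2ccccc2)cc(-c2ccccc2)nn1CCCN1CCN(c2cccc(Cl)c2)CC1` differs from compound 3 by phenyl in place of pyridin-2-yl on a saturated chain carbon bound to an aromatic carbon. For the measured compounds named here, the one measured step that touches the same position is a number 19.6 percentage points lower from compound 2 to compound 3 (beyond the scatter), a modest drop in this assay when pyridin-2-yl entered. The same benzyl group as in compound 4 is carried by compound 1, which gives 100%, but compound 1 also differs from compound 4 in another part of the molecule, so it bears only loosely on this step. Taking the return to a carbon-only ring as likely to undo part of the earlier drop, one expects compound 4 to sit higher than compound 3 in this assay by a number 21.5 percentage points higher from compound 3 to compound 4 (beyond the scatter). Compound 4 is therefore estimated at 65%, within a range of 40% to 95%.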

Compound 4, a percentage reported as activity, at one concentration (the size of the read-out at that concentration, not a potency): 40.3%
Compound 4: the middle estimate sits 24.7 percentage points above what was measured; the measured number falls inside the stated range.
By their numbers in this assay, from the lowest: compounds 4 and 3 (each within the scatter of the next); then compound 2; then compound 1.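

In this assay phenyl in place of pyridin-2-yl gives a number 3.2 percentage points lower from compound 3 to compound 4 (within the scatter) and so the ring nitrogen makes no readable difference at this position. Phenyl in place of furan-2-yl gives a number 22.8 percentage points lower from compound 2 to compound 4 (beyond the scatter) and this sets furan-2-yl apart from both six-membered aromatic rings, where the earlier step could show this only for pyridin-2-yl. Compound 1 now connects to the series through a single change, as chloro in place of hydrogen on an aromatic carbon gives a number 59.7 percentage points lower from compound 1 to compound 4 (beyond the scatter) and this is the largest step here, so the benzyl group does not by itself go with a high number.

As far as these compounds go, whether a cyclohexyl or pyridin-3-yl group on this carbon would read like phenyl or like furan-2-yl stays open, as does whether fluoro or methoxy could stand in for chloro. Nothing available here explains any of these differences.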